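This account rests on a few compounds, and the source may have more. Where it says the series, first, only, none or still open, it means among the compounds named here.

Measured in this series:
compound 1, `O/N=C(/Nc1cccc(Br)c1)c1ccc2occc2c1`: 440 nM
compound 2, `OCc1cc2cc(/C(=N\O)Nc3cccc(F)c3)ccc2o1`: 1700 nM
compound 3, `OCc1cc2cc(/C(=N\O)Nc3cccc(Cl)c3)ccc2o1`: 8000 nM

All three numbers come from an assay on isolated protein for inhibition of Indoleamine 2,3-dioxygenase 1 (Homo sapiens), read by spectrophotometry; on this read-out higher numbers stand for weaker inhibition and lower numbers for stronger inhibition. Compound 3 stands highest of the three; compound 2 is nearest to it and compound 1 furthest. For the measured compounds named here, the one single-change step among the measured compounds is a 4.7-fold higher number from compound 2 to compound 3 (0.67 log units; beyond the scatter), a modest worsening.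

Compound 4, `OCc1cc2cc(/C(=N\O)Nc3cccc(Br)c3)ccc2o1`, is not yet measured. It differs from compound 3 by bromo in place of chloro on an aromatic carbon. Going by the values given here, no measured pair compares bromo with chloro directly. Compound 1 carries bromo, but on a core lacking the hydroxymethyl group, so its gap to compound 3 mixes two changes and cannot be split. Among the compounds with values here, the only step that bears on the question is the fluoro-to-chloro one noted above; a further halogen change could continue that direction or reverse it, and the evidence does not decide. The expected step is therefore a 1.1-fold lower number from compound 3 to compound 4 (0.06 log units; within the scatter), essentially none beyond the scatter, with wide bounds. Compound 4 is estimated at 7000 nM, between 1800 nM and 28000 nM.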

Compound 4, half-maximal inhibitory concentration: 710 nM
Compound 4: middle estimate off by 9.9-fold (0.99 log units), on the high side, and the stated range ends above it.
By their numbers in this assay, from the lowest: compounds 1 and 4 (each within the scatter of the next); then compound 2; then compound 3.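

At this position, meta to a large group, the halogen series does not run in one direction: the change from chloro to bromo gives an 11-fold lower number from compound 3 to compound 4 (1.05 log units; beyond the scatter), reversing a 4.7-fold higher number from compound 2 to compound 3 (0.67 log units; beyond the scatter), and bromo also improves on fluoro, with a 2.4-fold lower number from compound 2 to compound 4 (0.38 log units; beyond the scatter). Among the three halogens on the shared core, chloro in compound 3 therefore stands apart from both neighbours rather than marking a trend. With bromo held fixed, hydroxymethyl in place of hydrogen gives a 1.6-fold higher number from compound 1 to compound 4 (0.21 log units; within the scatter), so that change has no effect beyond the scatter in this pair. Nothing available explains the chloro result.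

As far as these compounds go, whether iodo or methyl at this position would follow bromo or chloro remains open. So does whether an amine or carboxylic acid in place of hydroxymethyl would be tolerated equally.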